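A Second Fluoro Group on an Inactive Phenyl Ring

The source may hold more compounds than are shown below. What is called first, only, known or untested is meant among the compounds shown, and "the series" means these compounds.

Measured compounds:
compound 1 `Fc1ccc(N2CCN(Cc3ccn4c(CC5CC5)nnc4c3C(F)(F)F)CC2)c(Cl)c1`, > 10000 nM
compound 2 `Fc1ccccc1N1CCN(Cc2ccn3c(CC4CC4)nnc3c2C(F)(F)F)CC1`, > 10000 nM

Compound 1 `Fc1ccc(N2CCN(Cc3ccn4c(CC5CC5)nnc4c3C(F)(F)F)CC2)c(Cl)c1` was tested in a functional assay on HEK293 cells for agonist activity at metabotropic glutamate receptor 8 (Homo sapiens), read by a luciferase reporter and cAMP accumulation; a lower number here means that less compound is needed, a higher number that more compound is needed for the effect. In this assay compound 1 gives > 10000 nM, which is a limit of the assay and not a number. Compound 2 `Fc1ccccc1N1CCN(Cc2ccn3c(CC4CC4)nnc3c2C(F)(F)F)CC1` carries a 2-fluorophenyl in place of the 2-chloro-4-fluorophenyl on an amine nitrogen in a ring. In this assay compound 2 also gives > 10000 nM, again a limit rather than a number. The step that the two limits leave unreadable from compound 1 to compound 2 therefore cannot be read, since both ends sit at the limit of > 10000 nM in this assay, at which 2 of the 2 values shown sit.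

Compound 3 `Fc1ccc(N2CCN(Cc3ccn4c(CC5CC5)nnc4c3C(F)(F)F)CC2)c(F)c1` differs from compound 2 by fluoro in place of hydrogen on an aromatic carbon. Within the data shown here, the only measured step that touches this part of the molecule is the unreadable one from compound 1 to compound 2, so no direction or size can be taken from it. Both values at the limit suggest that this assay is likely to report a limit again for compound 3. Compound 3 is estimated at 10000 nM, with a range from 3000 nM to 30000 nM. The expected step is a number no higher from compound 2 to compound 3 (the limit leaves the size open), none beyond the scatter.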

Compound 3, half-maximal effective concentration: > 8000 nM
Compound 3 was reported as a limit; the forecaster's own chance of this, stated with the estimate: 85%; the middle value lies beyond the limit too.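

In this assay compound 3 gives > 8000 nM, which is a limit and not a number. Its steps from compound 1 and from compound 2 therefore cannot be read, in size or in direction. The compounds shown leave open whether any group on this phenyl ring gives a measurable value in this assay.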